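The compounds below may be only part of what the source reports. "The series", "measured", "known", "first", "only" and "open" are said of these compounds alone.

Notes on the series. Compound 2, `CC(C)C1(C(C)C)NC(=O)N(CN2CCN(C)CC2)C1=O`, gives 300 mg/kg in a functional assay on the whole organism (strain CD1) with Mus musculus as the target, in the maximal electroshock model, with a stated time of 0.5 h; a higher number here means that more compound is needed for the effect, a lower number that less compound is needed. Compound 1, `O=C1NC(c2ccccc2)(c2ccccc2)C(=O)N1CN1CCN(c2ccccc2)CC1`, gives 300 mg/kg in this assay, level with compound 2 at the digits shown, and the two together stand at the top of the three numbers. Among the compounds with values here, compound 3, `CN1CCN(CN2C(=O)NC(c3ccccc3)(c3ccccc3)C2=O)CC1`, gives 10 mg/kg, the lowest number of the set; against compound 2 the two values stand apart by more than the scatter, but the two compounds differ in two places and no single step is drawn between them.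

The step from compound 2 to compound 4, `CC(C)C1(C(C)C)NC(=O)N(CN2CCN(c3cccc(Cl)c3)CC2)C1=O`, is 3-chlorophenyl in place of methyl on an amine nitrogen in a ring. Within the data shown here, the one measured step that bears on it is the reverse exchange on the same ring nitrogen, a 30-fold lower number from compound 1 to compound 3 (1.48 log units; beyond the scatter), where the smaller group gave the lower number. Running it the other way, compound 4 is expected to need a higher dose than compound 2, so the estimated step is a 3.3-fold higher number from compound 2 to compound 4 (0.52 log units; beyond the scatter), with the reservation that compound 2 already sits at the top of the range seen. For compound 4 the estimate is 1000 mg/kg, between 300 mg/kg and 3000 mg/kg, with a real chance that only a limit is reported.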

Compound 4, minimum effective dose: 100 mg/kg
The estimate for compound 4 lay 10-fold (1.00 log units) above the measured number, and the stated range ends above it.
By their numbers in this assay, from the lowest: compound 3; then compound 4; then compounds 1 and 2 (each within the scatter of the next).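

In this assay, 3-chlorophenyl in place of methyl on this amine nitrogen gives a 3.0-fold lower number from compound 2 to compound 4 (0.48 log units; beyond the scatter), so on the core of compound 2 the aromatic group carries the lower number. On the core of compound 1 the direction runs the other way, with methyl in place of phenyl giving a 30-fold lower number from compound 1 to compound 3 (1.48 log units; beyond the scatter), which shows that the effect of an exchange at this nitrogen does not carry over unchanged from one core to the other. Nothing at hand explains this difference in direction.

Compounds 1 and 4 differ in both the core and the chlorine, so the part played by each remains unresolved. Also open, from the compounds shown here alone, is how a methoxy group in place of the chlorine, or an ethyl group on the ring nitrogen, would read on either core.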